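Iodophenyl to methoxypyridinyl on the amide carbonyl

The compounds below may be only part of what the source reports. "The series", "measured", "known", "first", "only" and "open" are said of these compounds alone.

Compound 1 (`COC(=O)c1scc(-c2ccc(NC(=O)c3cccc(I)c3)cc2)c1OC`) : 8240 nM
Compound 2 (`COC(=O)c1scc(-c2ccc(NC(=O)c3cccc(OC(F)(F)F)c3)cc2)c1OC`) : 7540 nM

Both values come from a functional assay on MDA-MB-231 cells (Homo sapiens) for antiproliferative activity, read by MTT assay, with a stated time of 24 h (a lower number here means a stronger inhibitor, a higher number a weaker inhibitor), where compound 1 stands level with compound 2, within the scatter. Compound 3 (`COC(=O)c1scc(-c2ccc(NC(=O)c3ccc(OC)nc3)cc2)c1OC`) has not been measured. It differs from compound 1 as follows: 6-methoxypyridin-3-yl in place of 3-iodophenyl on a carbonyl carbon. Among the measured compounds shown here, the only measured step, a 1.1-fold lower number from compound 1 to compound 2 (0.04 log units; within the scatter), exchanged just the iodo group, whereas here the whole 3-iodophenyl leaves, so it bears only loosely on this change. No step beyond the scatter is therefore expected in this assay, with wide uncertainty. For compound 3 the estimated value is 9000 nM, with an expected range from 3500 nM to 25000 nM. This estimate means an expected 1.1-fold higher number from compound 1 to compound 3 (0.04 log units; within the scatter).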

Compound 3, half-maximal inhibitory concentration: 15300 nM
Estimate against measurement, compound 3: 1.7-fold (0.23 log units) below; the range from low to high includes it.
By their numbers in this assay, from the lowest: compounds 2, 1 and 3 (each within the scatter of the next, the first and the last beyond it).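

In this assay, replacing the whole 3-iodophenyl on the carbonyl carbon with 6-methoxypyridin-3-yl gives a 1.9-fold higher number from compound 1 to compound 3 (0.27 log units; within the scatter) and so stays within the scatter. This position therefore accepts an exchange of the entire ring, carbon-only for one with a hetero atom, and not only of the iodo group. No measurement on these groups is available to explain this result.

The compounds shown leave open whether a six-membered aromatic ring is needed on this carbonyl carbon at all. They also do not show how an amine, a carboxylic acid or a longer chain would behave there.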